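This account rests on a few compounds, and the source may have more. Where it says the series, first, only, none or still open, it means among the compounds named here.

Working notes on the series. The core is shared by compound 1 (`Cc1ccc(S(=O)(=O)N[C@@H](CC(=O)NC(C)(C)C)C(=O)NCCNC(=O)c2cc(Cl)ccn2)cc1`) and compound 2 (`Cc1ccc(S(=O)(=O)N[C@@H](CC(=O)NC(C)(C)C)C(=O)NCCNC(=O)Nc2ccccc2)cc1`). In an ADME assay on Karpas-1106P cells (Homo sapiens) for cytotoxicity (on this read-out higher numbers stand for an effect only at larger amounts of compound and lower numbers for an effect already at smaller amounts), compound 1 gives > 11100 nM, which is a limit and not a number. In this assay compound 2 gives > 11100 nM, again a limit and not a number. Compound 2 therefore has no numerical position in the series, only (the limit of > 11100 nM in this assay, at which 2 of the 2 values shown sit).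

Compound 3 (`Cc1ccc(S(=O)(=O)N[C@@H](CC(=O)NC(C)(C)C)C(=O)NCCNC(=O)c2cccc(C(C)C)c2)cc1`) carries 3-isopropylphenyl in place of anilino on a carbonyl carbon. Going by the values given here, the one measured step that bears on this change is a step that the two limits leave unreadable from compound 1 to compound 2. It also concerns the group on a carbonyl carbon, but it offers no size to carry over, so no shift beyond the usual scatter is expected in this assay and no direction can be assigned. A report of a limit again is the likeliest outcome for compound 3. The expected change is a step that the limit leaves unreadable from compound 2 to compound 3, an estimate that rests on little. For compound 3 the estimated value is 12000 nM, with an expected range of 4000 nM to 30000 nM.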

Compound 3, half-maximal effective concentration: > 11100 nM
Compound 3: a limit, no number; the forecaster's own chance of this, stated with the estimate: 75%; the middle value lies beyond the limit too.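

No new step can be read in this assay: compound 1, compound 2 and compound 3 are all reported only as limits and not as numbers, so the steps among them stay unreadable. All three sit at the same place: the limit of > 11100 nM in this assay, at which 3 of the 3 values shown sit.

The compounds shown leave open at what concentration, if any, each would show an effect, and whether the groups on the carbonyl carbon differ at all.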